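Testing the Mirror Image of Compound 1

The source may report more compounds than this note shows. Statements on the series, on what has been measured and on what is new or still open speak of the compounds shown alone.

Going by the values given here, in a functional assay on K562 cells (Homo sapiens) for cytotoxicity, read by MTT assay, with a stated time of 48 h (a higher number here means a weaker inhibitor, a lower number a stronger inhibitor), compound 1 `COc1cc([C@@H]2C[C@]2(CO)C(=O)Nc2ccccc2Cl)cc(OC)c1OC` gives 16900 nM as one of only two actual numbers. Compound 3 `CCOC(=O)[C@]1(C(=O)Nc2ccccc2Cl)C[C@H]1c1cc(OC)c(OC)c(OC)c1` gives the other, 20700 nM and the two stand level. Ethoxycarbonyl in place of hydroxymethyl gives a 1.2-fold higher number from compound 1 to compound 3 (0.09 log units; within the scatter) with no real change. Compound 2 `COc1cc([C@@H]2C[C@]2(CO)C(=O)NCc2ccc(C)cc2)cc(OC)c1OC` shows only a limit of > 100000 nM and no number. Placing 4-methylbenzyl for 2-chlorophenyl on the amide nitrogen gives an at least 5.9-fold higher number from compound 1 to compound 2 (0.77 log units; beyond the scatter) as the one large step. Compound 4 `COc1cc([C@H]2C[C@@]2(CO)C(=O)Nc2ccccc2Cl)cc(OC)c1OC` carries the two compounds have the same atoms and bonds and differ only in configuration as drawn: 2 of 2 stereo elements differ (all stereocentres are inverted: mirror images); a stereocentre at a saturated ring carbon is drawn S in compound 1 and R in compound 4; a stereocentre at a saturated ring carbon is drawn S in compound 1 and R in compound 4 and neither measured step alters configuration. Among the compounds with values here, no mirror-image pair has been measured, so no step beyond the scatter is expected in this assay although the range must stay wide. The estimated change is a 1.3-fold higher number from compound 1 to compound 4 (0.11 log units; within the scatter) as an expectation only. For compound 4 the estimated value is 22000 nM with a range expected to span 7000 nM to 90000 nM around it.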

Compound 4, half-maximal inhibitory concentration: > 100000 nM
Compound 4 was reported as a limit; the forecaster's own chance of this, stated with the estimate: 20%; middle value at least 4.5-fold (0.65 log units) from the limit.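

In this assay, going by these compounds alone, inverting both stereocentres gives an at least 5.9-fold higher number from compound 1 to compound 4 (0.77 log units; beyond the scatter), the first sign that configuration at these ring carbons matters, since the earlier steps changed only groups. No group left or entered, so the drop in activity can be put down to configuration alone, because the structures are otherwise identical: the fact that compounds 1 and 4 differ only in the configuration as drawn. As far as these compounds go, compound 4 gives a limit, not a number, so the full size of the step stays unknown: the limit of > 100000 nM in this assay, at which 2 of the 4 values shown sit.

Still open, from the compounds shown here alone, is whether inverting only one stereocentre has the same result. Going by these compounds, it is also open how the mirror image of compound 3, or an aminomethyl or carboxylic acid group in place of hydroxymethyl, would behave.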